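Compound 3 takes on a 5-chloro-1H-indol-3-yl group

The source may hold more compounds than are shown below. What is called first, only, known or untested is meant among the compounds shown, and "the series" means these compounds.

In a functional assay on DU-145 cells (Homo sapiens) for inhibition, read by trypan blue exclusion, with a stated time of 96 h (on this read-out lower numbers stand for stronger inhibition of growth and higher numbers for weaker inhibition of growth), compound 3 `CSc1ccc(/C=C(\C(=O)c2ccc(Br)cc2)S(=O)(=O)c2ccc(C)cc2)cc1` gives 1000 nM. Compound 1 `O=C(/C(=C\c1c[nH]c2ccc(Cl)cc12)SCc1ccc(F)cc1)c1ccc(Br)cc1` gives 1000 nM, level with it, while compound 2 `Cc1ccc(S(=O)(=O)/C(=C/c2ccc(Br)cc2)C(=O)c2ccc(Br)cc2)cc1` gives 10000 nM, a higher number and so weaker inhibition of growth.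

The next structure is compound 4 `Cc1ccc(S(=O)(=O)/C(=C/c2c[nH]c3ccc(Cl)cc23)C(=O)c2ccc(Br)cc2)cc1`, which has not yet been measured. Reaching it from compound 3 involves one change: 5-chloro-1H-indol-3-yl in place of 4-(methylsulfanyl)phenyl on a double-bonded chain carbon bound to a double-bonded chain carbon. For the measured compounds named here, the only measured step on this aromatic group is a 10-fold lower number from compound 2 to compound 3 (1.00 log units; beyond the scatter), which lies beyond the scatter and shows that a smaller edit to this group can shift the number. That step does not involve the incoming group, however. Compound 1 does carry 5-chloro-1H-indol-3-yl and gives 1000 nM, but it differs from compound 4 elsewhere, so it offers only indirect support. On this evidence, no shift beyond the scatter is expected in this assay, and the estimated change is no change at the digits printed from compound 3 to compound 4 (within the scatter). For compound 4, the estimated value is 1000 nM, with an expected range of 200 nM to 5000 nM.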

Compound 4, concentration for 50% growth inhibition: 10000 nM
Compound 4: middle estimate off by 10-fold (1.00 log units), on the low side; measured number above the stated range.
By their numbers in this assay, from the lowest: compounds 1 and 3 (each within the scatter of the next); then compounds 2 and 4 (each within the scatter of the next).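

In this assay, with (4-methylphenyl)sulfonyl held in place, swapping in the 5-chloro-1H-indol-3-yl group gives a 10-fold higher number from compound 3 to compound 4 (1.00 log units; beyond the scatter) and so loses what 4-(methylsulfanyl)phenyl gained, while the comparison with 4-bromophenyl gives no change at the digits printed from compound 2 to compound 4 (within the scatter). The group therefore does not bring the number of compound 1 with it, since the change at the other place, (4-methylphenyl)sulfonyl in place of (4-fluorobenzyl)sulfanyl, gives a 10-fold higher number from compound 1 to compound 4 (1.00 log units; beyond the scatter) and shows that the group on that carbon matters as well. Nothing measured here explains these steps.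

Going by these compounds, it remains open whether a 4-methoxyphenyl or a 4-aminophenyl group at this place would match 4-(methylsulfanyl)phenyl. On these data alone, it is also open how 4-(methylsulfanyl)phenyl would behave alongside (4-fluorobenzyl)sulfanyl.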